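This account rests on a few compounds, and the source may have more. Where it says the series, first, only, none or still open, it means among the compounds named here.

Of the compounds shown here, three sharing one core have been tested in a functional assay on HeLa cells (Homo sapiens) for inhibition, read by MTT assay, with a stated time of 48 h; on this read-out higher numbers stand for weaker inhibition and lower numbers for stronger inhibition. Among the compounds with values here, compound 1 `COc1ccc(-c2nc3cc(/C=C4\SC(=O)NC4=O)ccc3[nH]2)cc1OC` gives 7830 nM, and compound 2 `COc1cc(OC)c(-c2nc3cc(/C=C4\SC(=O)NC4=O)ccc3[nH]2)cc1OC` gives 15400 nM; the single measured step, a 2.0-fold higher number from compound 1 to compound 2 (0.29 log units; within the scatter), came from a methoxy in place of hydrogen on an aromatic carbon. Compound 3 `COc1cc(-c2nc3cc(/C=C4\SC(=O)N(CC(=O)N5CCCCC5)C4=O)ccc3[nH]2)cc(OC)c1OC` gives 23300 nM, a value within the scatter of that of compound 2. Compound 2 therefore stands second highest of the three numbers, within the scatter of both the others. Compound 4 `COc1cc(OC)c(-c2nc3cc(/C=C4\SC(=O)N(Cc5cccc(C)c5)C4=O)ccc3[nH]2)cc1OC` differs from compound 2 by 3-methylbenzyl in place of hydrogen on an amide-type nitrogen in a ring. Within the data shown here, no measured step isolates this change: the one step known concerns a methoxy group, and no single-point step links compound 3 to compound 2. The expected step is a 1.0-fold lower number from compound 2 to compound 4 (0.01 log units; within the scatter), nothing beyond the scatter. Compound 4 is estimated at 15000 nM, ranging from 5000 nM to 50000 nM.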

Compound 4, half-maximal inhibitory concentration: 180 nM
For compound 4 the middle estimate is 83-fold (1.92 log units) above the measured one; measured number outside the range, below it.
By their numbers in this assay, from the lowest: compound 4; then compounds 1, 2 and 3 (each within the scatter of the next, the first and the last beyond it).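

Putting 3-methylbenzyl in place of the hydrogen on the amide-type nitrogen brings an 86-fold lower number from compound 2 to compound 4 (1.93 log units; beyond the scatter) in this assay and so marks this nitrogen as a place where one change can matter greatly. The only earlier step, the methoxy change on an aromatic carbon, stayed within the scatter, so this is the first single change shown to move the number beyond it.

On these data alone, whether the aromatic ring or its methyl group drives this drop stays open, as does the outcome with plain benzyl, an ethyl chain or a carboxylic acid on this nitrogen. Nothing available here explains why the effect is so large.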